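A few compounds are considered here, and "the series" means these few. Any claim that something is new, unique, unknown or untested is made for them only; others in the source may bear on it.

Three compounds have been measured in a functional assay on T47D cells (Homo sapiens) for cytotoxicity, read by CCK-8 assay; a higher number here means a weaker inhibitor, a lower number a stronger inhibitor:
Compound 1 `Oc1ccc(-c2cc(-c3cccs3)cc(-c3cccc(O)c3)n2)cc1` gives 780 nM.
Compound 2 `Oc1ccc(-c2cc(-c3cccs3)cc(-c3ccc(O)cc3)n2)cc1` gives 11700 nM.
Compound 3 `Oc1cccc(-c2cc(-c3ccsc3)cc(-c3ccccc3O)n2)c1` gives only a limit of the assay, > 50000 nM.

Compounds 1 and 2 share one core and differ in a single place: 4-hydroxyphenyl in place of 3-hydroxyphenyl on an aromatic carbon. That change produced a 15-fold higher number from compound 1 to compound 2 (1.18 log units; beyond the scatter). Compound 3 has a different core; how the cores of compound 1 and compound 3 differ is not broken down here. Compound 4 `Oc1ccc(-c2cc(-c3ccsc3)cc(-c3ccccc3O)n2)cc1` has not yet been measured in this assay. It differs from compound 3 by 4-hydroxyphenyl in place of 3-hydroxyphenyl on an aromatic carbon. This is the same kind of change as from compound 1 to compound 2, but not the same: in compound 3 the place is meta to a 2-hydroxyphenyl group and to a thiophen-3-yl group, whereas in compound 1 it is meta to a 4-hydroxyphenyl group and to a thiophen-2-yl group.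

Compound 3 already sits at the limit of > 50000 nM in this assay, at which 1 of the 3 values shown sits. The earlier change weakened inhibition, as a 15-fold higher number from compound 1 to compound 2 (1.18 log units; beyond the scatter) shows. Compound 4 is therefore expected to give about 150000 nM, most likely again reported only as a limit, with a range from 50000 nM to 600000 nM. The expected step is a step that the limit leaves unreadable from compound 3 to compound 4.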

Compound 4, half-maximal inhibitory concentration: > 50000 nM
Compound 4: only a limit was reported; the forecaster's own chance of this, stated with the estimate: 85%; the middle value is on the limit's open side.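

Compound 3 and compound 4 both reach only a limit of the assay, not a number, so no step between them can be read: the limit of > 50000 nM in this assay, at which 2 of the 4 values shown sit.

On these data alone, whether 4-hydroxyphenyl in place of 3-hydroxyphenyl changes anything on this core stays open.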